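The source may hold more compounds than are shown below. What is called first, only, known or untested is meant among the compounds shown, and "the series" means these compounds.

Of the compounds shown here, two built on one shared core have been tested in a functional assay on the whole organism with Mus musculus as the target; a lower number here means that less compound is needed, a higher number that more compound is needed for the effect. Compound 1, `Nc1nnc(-c2ccccc2OCc2ccc(F)cc2)o1`, gives 2.5 mg/kg. Compound 2, `Sc1nnc(-c2ccccc2OCc2ccccc2)o1`, reaches only the limit of the assay, > 100 mg/kg, which is a limit and not a measured number, as stated for (the limit of > 100 mg/kg in this assay, at which 1 of the 2 values shown sits). The two compounds differ in more than one place, so their values show only that one is active and the other not within the tested range.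

Compound 3 is `c1ccc(COc2ccccc2-c2nnc(SCc3ccccc3)o2)cc1`. It differs from compound 2 in a single place: benzyl in place of hydrogen on a sulfur. For the measured compounds named here, no pair of measured compounds shows this change, so its size in this assay cannot be read from what is known. The step of an at least 3.3-fold lower number from compound 2 to compound 3 (0.52 log units; beyond the scatter) is expected to move toward a smaller dose, with wide uncertainty. Compound 3 is estimated at 30 mg/kg, within a range from 5 mg/kg to 150 mg/kg.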

Compound 3, dose for half-maximal effect: > 100 mg/kg
Compound 3 gave a limit, no number (the forecaster's own chance of this, stated with the estimate: 40%); at least 3.3-fold (0.52 log units) between middle value and limit.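

Compound 2 and compound 3 both stop at a limit of the assay and not at a number, so no step between them can be read: the limit of > 100 mg/kg in this assay, at which 2 of the 3 values shown sit.

The compounds shown leave open how far benzyl in place of hydrogen on a sulfur shifts the dose in this assay, and which of the differences between compound 1 and compound 2 accompanies the measured value of compound 1.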